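A few compounds are considered here, and "the series" means these few. Any claim that something is new, unique, unknown or untested is made for them only; others in the source may bear on it.

Measured compounds:
compound 1 `O=[N+]([O-])c1cc(Cn2nnnc2[Se]Cc2ccccc2)cc([N+](=O)[O-])c1`: 85000 nM
compound 2 `O=[N+]([O-])c1cc(Cn2nnc([Se]Cc3ccccc3)n2)cc([N+](=O)[O-])c1`: 118000 nM
compound 3 `O=[N+]([O-])c1cc(Cn2nnnc2SCc2ccccc2)cc([N+](=O)[O-])c1`: 115000 nM

All three were tested in an ADME assay on CHO-K1 cells (Cricetulus griseus) for cytotoxicity, read by MTT assay, with a stated time of 24 h; on this read-out lower numbers stand for stronger inhibition and higher numbers for weaker inhibition. Compound 1 and compound 2 are built from the same atoms joined differently; the difference between the two cores is not broken down here. Compound 3 arises from compound 1 by a group of 8 heavy atoms (7 carbon, 1 sulfur; one six-membered aromatic ring of carbon only) in place of a group of 8 heavy atoms (7 carbon, 1 selenium; one six-membered aromatic ring of carbon only), on an aromatic carbon, and this gives a 1.4-fold higher number from compound 1 to compound 3 (0.13 log units; within the scatter). Compound 4 `O=[N+]([O-])c1cc(Cn2nnc(SCc3ccccc3)n2)cc([N+](=O)[O-])c1` is not yet measured; it arises from compound 2 by the same kind of change, (a group of 8 heavy atoms (7 carbon, 1 sulfur; one six-membered aromatic ring of carbon only) in place of a group of 8 heavy atoms (7 carbon, 1 selenium; one six-membered aromatic ring of carbon only), on an aromatic carbon), though in compound 2 the place is two ring bonds from the ring atom that bears a large group, where in compound 1 it is next to that ring atom. Because a 1.4-fold higher number from compound 1 to compound 3 (0.13 log units; within the scatter) stayed within the scatter, compound 4 is expected to show a 1.1-fold higher number from compound 2 to compound 4 (0.06 log units; within the scatter). Compound 4 is estimated at 135000 nM, between 80000 nM and 230000 nM.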

Compound 4, half-maximal inhibitory concentration: 148000 nM
The estimate for compound 4 lay 1.1-fold (0.04 log units) below the measured number; measured number inside the range.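

In this assay, benzylsulfanyl in place of the selenium-linked benzyl group gives a 1.3-fold higher number from compound 2 to compound 4 (0.10 log units; within the scatter). The change reads alike on the two cores: the same change on two cores in this assay, a 1.4-fold higher number (0.13 log units; within the scatter) from compound 1 to compound 3 and a 1.3-fold higher number (0.10 log units; within the scatter) from compound 2 to compound 4, 1.1-fold (0.03 log units) apart, within the scatter of two such steps. Both steps lie within the scatter, so this shows only that exchanging selenium for sulfur does not move the read-out measurably on these two cores; it shows no real shift that carries from one core to the other, and it says nothing about any other core in the series.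

The compounds shown leave open whether the exchange stays this small with a longer chain in place of the benzyl group. They also leave open what happens with an amine or a carboxylic acid in place of a nitro group.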